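Amide-side change in a pyridinyl alkyne series

The compounds below may be only part of what the source reports. "The series", "measured", "known", "first", "only" and "open" are said of these compounds alone.

Compound 3, `CC(C)[C@@H](C)NC(=O)c1ccc(C#Cc2cccc(F)c2)cn1`, gives 22.5% in an ADME assay on HEK293 cells for agonist activity at metabotropic glutamate receptor 5 (Rattus norvegicus), read by fluorescence and calcium flux; a lower number here means a smaller maximal response, a higher number a larger maximal response. Of the three measured compounds it stands second highest: compound 2, `C[C@@H](NC(=O)c1ccc(C#Cc2ccncc2)cn1)C(C)(C)O`, gives 22.4%, within the scatter of compound 3, while compound 1, `C[C@@H](NC(=O)c1ccc(C#Cc2ccc(F)cc2F)cn1)C(C)(C)O`, gives 38.2%, beyond the scatter above it. Among the compounds with values here, the only step measured between single-point neighbours is a number 15.8 percentage points lower from compound 1 to compound 2 (beyond the scatter), and it concerns the aryl on the triple-bonded carbon, not the amide side.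

Compound 4, `CC1(CCNC(=O)c2ccc(C#Cc3cccc(F)c3)cn2)COC1`, differs from compound 3 in one place: 2-(3-methyloxetan-3-yl)ethyl in place of 1,2-dimethylpropyl on an amide-type nitrogen. No measured step touches this position, so the change from a 1,2-dimethylpropyl to a 2-(3-methyloxetan-3-yl)ethyl on the amide-type nitrogen has no direct precedent among these compounds. In the absence of any such guide, the account expects the step of a number 0.5 percentage points lower from compound 3 to compound 4 (within the scatter) to stay within the usual scatter, while allowing a wide range in both directions. Compound 4 is therefore estimated at 22%, expected between 8% and 40%.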

Compound 4, largest response reached (reported as efficacy), in percent of the reference or control that the assay uses: 16.3%
Estimate against measurement, compound 4: 5.7 percentage points above; the range from low to high includes it.
By their numbers in this assay, from the lowest: compounds 4, 2 and 3 (each within the scatter of the next); then compound 1.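

The amide-type nitrogen now has its first measured step in this assay, a number 6.2 percentage points lower from compound 3 to compound 4 (within the scatter). This shows that a substantial change of group at this position, from an open-chain 1,2-dimethylpropyl with a defined stereocentre to a 2-(3-methyloxetan-3-yl)ethyl with a four-membered ring and an oxygen, can leave the maximal response within the scatter, at least with the aryl group that compound 3 and compound 4 share. No evidence is available here that explains this result or ties it to any property of either group.

From the compounds shown here alone, whether the same change would stay within the scatter with the 2,4-difluorophenyl of compound 1 or the pyridin-4-yl of compound 2 remains open. So does the outcome of a primary amine, a carboxylic acid or a longer chain at this position.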